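The compounds below may be only part of what the source reports. "The series", "measured", "known", "first", "only" and "open" are said of these compounds alone.

Of the compounds shown here, three have been tested in an assay on isolated protein for inhibition of vitamin D3 receptor (Homo sapiens), read by fluorescence polarization (a lower number here means a stronger inhibitor, a higher number a weaker inhibitor), and none of them gave a number. Compound 1 `CS(=O)(=O)c1ccc(C(=O)N2CCC(C(=O)N3CCN(c4ccc(F)cc4)CC3)CC2)cc1[N+](=O)[O-]` sits at the limit of this assay, > 60000 nM. Compound 2 `CS(=O)(=O)c1ccc(C(=O)NCCC(=O)N2CCc3ccccc32)cc1[N+](=O)[O-]` likewise stops at the limit, > 60000 nM. Compound 3 `CN(Cc1ccccc1F)C(=O)C1CCN(C(=O)c2ccc(S(C)(=O)=O)c([N+](=O)[O-])c2)CC1` also reaches only the limit, > 60000 nM. Where compound 3 stands is therefore only bounded, and all three measured values share that ceiling (the limit of > 60000 nM in this assay, at which 3 of the 3 values shown sit). Compound 4 `CS(=O)(=O)c1ccc(C(=O)N2CCC(C(=O)N3CCc4ccccc4C3)CC2)cc1[N+](=O)[O-]` keeps the core of compound 3 and differs in one place (1,2,3,4-tetrahydroisoquinolin-2-yl in place of (2-fluorobenzyl)(methyl)amino on a carbonyl carbon), that is, 1,2,3,4-tetrahydroisoquinolin-2-yl in place of (2-fluorobenzyl)(methyl)amino on a carbonyl carbon. Within the data shown here, no measured pair differs in a single place, so no step gives a calibration. With every measured compound at the limit, the expected step is a step that the limit leaves unreadable from compound 3 to compound 4, nothing beyond the scatter. Compound 4 is estimated at 100000 nM, between 40000 nM and 300000 nM, most likely again only a limit.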

Compound 4, half-maximal inhibitory concentration: > 60000 nM
Compound 4 was reported as a limit; the forecaster's own chance of this, stated with the estimate: 85%; the middle value lies beyond the limit too.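

In this assay compound 3 and compound 4 both sit at a limit of the assay, and no step can be read between them. The compounds shown leave open what structure would give a readable value in this assay rather than a limit.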